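The source may hold more compounds than are shown below. What is called first, only, known or untested is meant among the compounds shown, and "the series" means these compounds.

Series notes, shared core of compound 1 `ONc1cccc(CNc2cc(Br)cc3[nH]ncc23)c1`. In an assay for inhibition of Indoleamine 2,3-dioxygenase 1 (Homo sapiens), with a stated time of 1 h, tested at 10 uM (a higher number here means more inhibition at the concentration tested (going by the name of the read-out), a lower number less inhibition), compound 1 gives 53%. Compound 2 `N#Cc1ccc(CNc2cc(Br)cc3[nH]ncc23)cc1` gives 70% in this assay, a gap to compound 1 beyond the usual scatter, with compound 2 the higher number. Compound 3 `Oc1ccc(CNc2cc(Br)cc3[nH]ncc23)cc1Cl` gives 60% in this assay, a number within the scatter of compound 1.

Compound 4 `O=C(O)Nc1cccc(CNc2cc(Br)cc3[nH]ncc23)c1` differs from compound 1 in one place: carboxy in place of hydroxy on a nitrogen on an aromatic ring. For the measured compounds named here, no pair among the measured compounds carries a comparable change, so no measured step guides the expectation. The difference is small in count and keeps the donor and acceptor pattern; no step beyond the scatter is expected in this assay, in either direction. The step from compound 1 to compound 4 is estimated as a number 3 percentage points lower from compound 1 to compound 4 (within the scatter). Compound 4 is expected to give about 50% in this assay, with a range from 28% to 70%.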

Compound 4, a percentage reported as inhibition, at one concentration (the size of the read-out at that concentration, not a potency): 57%
Beside the measured number, compound 4's estimate is 7 percentage points below it, within the range that was stated.
By their numbers in this assay, from the lowest: compounds 1, 4, 3 and 2 (each within the scatter of the next, the first and the last beyond it).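

Carboxy in place of hydroxy on a nitrogen on an aromatic ring is the first one-place change in the series, and in this assay it gives a number 4 percentage points higher from compound 1 to compound 4 (within the scatter) for this exchange. This place therefore takes carboxyamino for hydroxyamino, with two more heavy atoms, without a step that stands out from the scatter. Nothing measured on these compounds bears on why the number holds.

From the compounds shown here alone, whether an amine or a longer chain in place of the hydroxyamino group would hold the number as well remains open. A single step also leaves open whether this exchange reads the same on other members of the series.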